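Aryl substituent changes on the cyclopentyl urea series

The source may report more compounds than this note shows. Statements on the series, on what has been measured and on what is new or still open speak of the compounds shown alone.

The shared core carries a 2,6-diisopropylphenyl urea linked through a methylene to a cyclopentane bearing an aryl group. Compound 1 `CC(C)c1cccc(C(C)C)c1NC(=O)NCC1(c2ccc(C(C)(C)C)cc2)CCCC1` has a 4-tert-butylphenyl group; in an assay on microsomes for inhibition of acyl-CoA:cholesterol acyltransferase (Oryctolagus cuniculus) (on this read-out higher numbers stand for weaker inhibition and lower numbers for stronger inhibition), compound 1 gives 63 nM. Compound 2 `CC(C)c1cccc(C(C)C)c1NC(=O)NCC1(c2ccc(Cl)cc2)CCCC1` carries 4-chlorophenyl instead, and in this assay compound 2 gives 32 nM. Compound 3 `CC(C)c1cccc(C(C)C)c1NC(=O)NCC1(c2ccc(OCc3ccccc3)cc2)CCCC1` carries 4-benzyloxyphenyl, and in this assay compound 3 gives 34 nM. Compound 2 shows the lowest of the three numbers, but its distance to compound 3 and to compound 1 lies within the scatter, so the three aryl substituents cannot be told apart on these data.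

Compound 4 `CC(C)c1cccc(C(C)C)c1NC(=O)NCC1(c2cccc([N+](=O)[O-])c2)CCCC1` is the next member: 3-nitrophenyl in place of 4-chlorophenyl on a saturated ring carbon. Among the compounds with values here, the steps that bear on it are the exchanges of the aryl substituent already made, a 2.0-fold lower number from compound 1 to compound 2 (0.29 log units; within the scatter) and a 1.1-fold higher number from compound 2 to compound 3 (0.03 log units; within the scatter), both within the scatter. Within the data shown here, no measured compound changes the ring position or introduces a nitro group, so the step to compound 4 has no direct precedent. Given that the measured exchanges were flat, the expected step of a 1.6-fold higher number from compound 2 to compound 4 (0.19 log units; within the scatter) is small, with no direction beyond the scatter. The estimate for compound 4 in this assay is 50 nM, within a range from 15 nM to 170 nM.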

Compound 4, half-maximal inhibitory concentration: 51 nM
Estimate against measurement, compound 4: 1.0-fold (0.01 log units) below; the range from low to high includes it.
By their numbers in this assay, from the lowest: compounds 2, 3, 4 and 1 (each within the scatter of the next).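

The exchange of 4-chlorophenyl for 3-nitrophenyl on a saturated ring carbon gives a 1.6-fold higher number from compound 2 to compound 4 (0.20 log units; within the scatter) in this assay and the exchange of 4-(tert-butyl)phenyl for the same group gives a 1.2-fold lower number from compound 1 to compound 4 (0.09 log units; within the scatter) in this assay as well. The flat picture among the 4-chlorophenyl, 4-(tert-butyl)phenyl and 4-benzyloxyphenyl compounds therefore extends to an aryl group that differs in both its substituent and that substituent's ring position, with 2 hydrogen-bond acceptors entering where 4-chlorophenyl has 0, and none of the four compounds goes against this picture. No supporting data are available to explain this flat result.

Because the nitro group and its ring position change together in compound 4, the contribution of each cannot be separated here, and a 4-nitrophenyl or 3-chlorophenyl group would be needed to pull them apart. It also remains open whether the flat picture would hold for an aryl group carrying an amine or a carboxylic acid, since every substituent shown is uncharged.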